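Chloro for trifluoromethyl on the aryl ring of compound 3

A few compounds are considered here, and "the series" means these few. Any claim that something is new, unique, unknown or untested is made for them only; others in the source may bear on it.

Working notes on the series. Compound 1 `CC1=CSC(O)(c2cccc([N+](=O)[O-])c2)c2noc(=O)n21` in a functional assay on A2780/DX3 cells (Homo sapiens) for antiproliferative activity, read by MTT assay, with a stated time of 3 days (a higher number here means a weaker inhibitor, a lower number a stronger inhibitor), gives 129000 nM. Compound 3 `CC1=CSC(O)(c2cccc(C(F)(F)F)c2)c2noc(=O)n21` in this assay gives 71000 nM, the lowest of the two numbers in hand, though the step of a 1.8-fold lower number from compound 1 to compound 3 (0.26 log units; within the scatter) leaves the two indistinguishable. Compound 2 `O=c1onc2n1C=CSC2(O)c1ccc(Cl)cc1`, built on a different core, returns in this assay only a limit of the assay, > 100000 nM.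

Compound 4 `CC1=CSC(O)(c2cccc(Cl)c2)c2noc(=O)n21` differs from compound 3 by chloro in place of trifluoromethyl on an aromatic carbon. Within the data shown here, no measured pair exchanges chloro for trifluoromethyl; the one measured step at this place, a 1.8-fold lower number from compound 1 to compound 3 (0.26 log units; within the scatter), stays within the scatter. On that basis the change to compound 4 is expected to give no step beyond the scatter, a 1.3-fold higher number from compound 3 to compound 4 (0.10 log units; within the scatter). Compound 4 is therefore estimated at 90000 nM, with a range from 35000 nM to 250000 nM. Since the limit of > 100000 nM in this assay, at which 1 of the 3 values shown sits, shows how weak this series runs, compound 4 may also come back only as a limit rather than a number.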

Compound 4, half-maximal inhibitory concentration: > 100000 nM
Compound 4 ended at the assay's limit; the forecaster's own chance of this, stated with the estimate: 35%; middle value at least 1.1-fold (0.04 log units) from the limit.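

In this assay, chloro in place of trifluoromethyl on this aromatic carbon gives an at least 1.4-fold higher number from compound 3 to compound 4 (0.14 log units; that floor lies within the scatter), so the change has only a floor and no measured size, and that floor does not separate the two groups. Among these compounds, the step from nitro to chloro cannot be read, which leaves compound 1 and compound 3 as the only pair at this place with numbers on both sides, and their step lies within the scatter. This place has therefore shown no step beyond the scatter so far, and a second compound now sits at the limit of the assay: the limit of > 100000 nM in this assay, at which 2 of the 4 values shown sit.

On these data alone, whether an amine or a carboxylic acid on this aromatic carbon would give a step beyond the scatter remains open. As far as these compounds go, how far chloro actually lies from trifluoromethyl also remains open.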